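The source may hold more compounds than are shown below. What is called first, only, known or untested is meant among the compounds shown, and "the series" means these compounds.

Working notes on the series. For the measured compounds named here, compound 1 `CCN(CC)c1ccc(N2C(=O)CSC2c2cccc(C(=O)NCCCCc3ccccc3)c2)cc1` is measured in a functional assay on HOS-TE85 cells (Homo sapiens) for inhibition, read by CCK-8 assay, with a stated time of 72 h (on this read-out lower numbers stand for stronger inhibition and higher numbers for weaker inhibition), only as a limit, > 1000 nM, so no number is known for it; that is the one value resting at the limit of > 1000 nM in this assay, at which 1 of the 3 values shown sits. Compound 2 `COc1ccccc1N1C(=O)CSC1c1cc(F)cc(C(=O)NCCCCc2ccccc2)c1` gives 40.9 nM in this assay. Compound 3 `O=C(NCCCCn1cccn1)c1cccc(C2SCC(=O)N2c2cc(Br)ccn2)c1` gives 105 nM in this assay. Compound 4 `O=C(NCCCCc1ccccc1)c1cccc(C2SCC(=O)N2c2cccc(F)c2)c1` is not yet measured; it differs from compound 1 in one place: 3-fluorophenyl in place of 4-(diethylamino)phenyl on an amide-type nitrogen in a ring. Going by the values given here, no step between two measured compounds is available to set a size for this change, and the limit on compound 1 leaves its start point open. Since compound 2, with another group on that nitrogen, reaches 40.9 nM, the step from compound 1 to compound 4 is expected to be large toward stronger inhibition, an at least 6.6-fold lower number from compound 1 to compound 4 (0.82 log units; beyond the scatter). Compound 4 is estimated at 150 nM, within 40 nM to 600 nM.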

Compound 4, half-maximal inhibitory concentration: 32.4 nM
Estimate against measurement, compound 4: 4.6-fold (0.67 log units) above, and the stated range ends above it.
By their numbers in this assay, from the lowest: compounds 4 and 2 (each within the scatter of the next); then compound 3. At a limit, above all of these: compound 1.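

In this assay, the group on the amide-type nitrogen in a ring strongly sets the read-out: 3-fluorophenyl in place of 4-(diethylamino)phenyl gives an at least 30-fold lower number from compound 1 to compound 4 (1.48 log units; beyond the scatter). With the rest of the structure unchanged, a 4-(diethylamino)phenyl group is thus not needed at this position for a low number. Compound 1 rests at a limit, so the step has a lower bound only: the limit of > 1000 nM in this assay, at which 1 of the 4 values shown sits.

As far as these compounds go, it remains open whether the step comes from losing the diethylamino group or from gaining the fluorine. An unsubstituted phenyl or a 4-(dimethylamino)phenyl group on that nitrogen would help separate the two.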